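A few compounds are considered here, and "the series" means these few. Any claim that something is new, unique, unknown or untested is made for them only; others in the source may bear on it.

In a physicochemical assay for solubility, with a stated time of 24 h, tested at 30 mg/mL (a lower number here means a less soluble compound, a higher number a more soluble compound), compound 1 (`O=C(CCCCCCNc1c(Nc2ccccc2)c(=O)c1=O)NO`) gives 1800000 nM, compound 2 (`CC[C@H](Nc1c(NCCCCCC(=O)NO)c(=O)c1=O)c1ccccc1`) gives 57000000 nM and compound 3 (`Cc1ccccc1[C@H](C)Nc1c(NCCCCCC(=O)NO)c(=O)c1=O`) gives 47000000 nM. Compound 3 therefore stands level with compound 2, within the scatter, and well clear of compound 1, beyond the scatter. Compound 4 (`Cc1ccc([C@H](C)Nc2c(NCCCCCC(=O)NO)c(=O)c2=O)cc1`) has not yet been measured. It has the same atoms as compound 3, joined differently: 4-methylphenyl in place of 2-methylphenyl on a saturated chain carbon bound to a nitrogen on an aromatic ring and a saturated chain carbon. Among the compounds with values here, no measured pair shows what such a change does, so the only guide is compound 3 itself, and no step beyond the scatter is expected in this assay, in either direction. The expected step is a 1.1-fold lower number from compound 3 to compound 4 (0.05 log units; within the scatter). For compound 4 the estimated value is 42000000 nM, with an expected range of 16000000 nM to 90000000 nM.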

Compound 4, solubility: 5600000 nM
Compound 4: the middle estimate sits 7.5-fold (0.88 log units) above what was measured; the whole stated range lies above it.
By their numbers in this assay, from the lowest: compound 1; then compound 4; then compounds 3 and 2 (each within the scatter of the next).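

In this assay, 4-methylphenyl in place of 2-methylphenyl on this saturated chain carbon gives an 8.4-fold lower number from compound 3 to compound 4 (0.92 log units; beyond the scatter) with no change in the atoms present. Where the methyl stands on the phenyl ring therefore matters in this assay, which no earlier pair could show, as none of the earlier compounds differ in one place only. Nothing at hand accounts for this step. The compounds shown leave open whether a chlorine or a methoxy group in place of the methyl would show the same dependence on ring position. Going by these compounds, whether the same step appears with an ethyl group on the chain carbon, as in compound 2, also stays open.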